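Working notes on the step from compound 3 to compound 4

The compounds below may be only part of what the source reports. "The series", "measured", "known", "first", "only" and "open" are said of these compounds alone.

The series is followed in a functional assay on MIA PaCa-2 cells (Homo sapiens) for inhibition, read by MTT assay, with a stated time of 3 days; a lower number here means a stronger inhibitor, a higher number a weaker inhibitor. Compound 1, `CCN(CC)S(=O)(=O)c1ccc(S(=O)(=O)N2CCC[C@@H](C(=O)NC3CN(C(=O)C4CC4)C3)C2)cc1`, gives > 10000 nM in this assay, which is a limit of the assay and not a number. Compound 2, `CCN(CC)S(=O)(=O)c1ccc(S(=O)(=O)N2CCC[C@@H](C(=O)N(C)C(C)C)C2)cc1`, gives > 10000 nM in this assay, again a limit. Among the compounds with values here, the single change between these two, isopropyl(methyl)amino in place of (1-(cyclopropylcarbonyl)azetidin-3-yl)amino on a carbonyl carbon, gives a step that the two limits leave unreadable from compound 1 to compound 2. Compound 3, `CCOC(=O)[C@@H]1CCCN(S(=O)(=O)c2ccc(S(=N)(=O)N(CC)CC)cc2)C1`, gives > 10000 nM in this assay, a limit as well. Compound 3 thus stands where every compound shown stands, at the limit of > 10000 nM in this assay, at which 3 of the 3 values shown sit, with no numbered value in the set to rank it against.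

Compound 4, `CCCN(CCC)S(=O)(=O)c1ccc(S(=O)(=O)N2CCC[C@@H](C(=O)OCC)C2)cc1`, is not yet measured. It differs from compound 3 by a group of 10 heavy atoms (6 carbon, 1 nitrogen, 2 oxygen, 1 sulfur; no ring) in place of a group of 8 heavy atoms (4 carbon, 2 nitrogen, 1 oxygen, 1 sulfur; no ring), on an aromatic carbon. Within the data shown here, no measured step touches this part of the structure, and the only measured step at all, the one from compound 1 to compound 2, is itself unreadable between two limits, so nothing supports an expectation of a step beyond the scatter in either direction. The step from compound 3 to compound 4 is therefore expected as a step that the limit leaves unreadable from compound 3 to compound 4, a value near the limit once more. Compound 4 is estimated at 20000 nM in this assay, with a range from 8000 nM to 60000 nM, and the assay is expected most likely to report only a limit.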

Compound 4, half-maximal inhibitory concentration: > 10000 nM
Compound 4: only a limit was reported; the forecaster's own chance of this, stated with the estimate: 85%; the middle value does not contradict the limit.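

Compound 3 and compound 4 both give only a limit of the assay and not a number, so no step can be read between them: the limit of > 10000 nM in this assay, at which 4 of the 4 values shown sit.

The compounds shown leave open how large that step is, and which change to the shared core, if any, would give a numbered value in this assay.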